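The source may hold more compounds than are shown below. What is called first, only, known or untested is meant among the compounds shown, and "the series" means these compounds.

Measured in a functional assay on CCRF-CEM cells (Homo sapiens), read by MTT assay, with a stated time of 72 h; on this read-out higher numbers stand for weaker inhibition and lower numbers for stronger inhibition:

- compound 1 `C#Cc1cn([C@@H]2O[C@H](CO)[C@@H](O)[C@H]2O)c2ncnc(SC)c12`: > 20000 nM
- compound 2 `CNc1ncnc2c1c(-c1cc3ccccc3o1)cn2[C@@H]1O[C@H](CO)[C@@H](O)[C@H]1O`: > 20000 nM

Neither entry is a true number. In this assay compound 2 reads > 20000 nM, and this is a limit. So compound 2 has no exact position on the scale, and the same is true of compound 1. The whole record so far amounts to the limit of > 20000 nM in this assay, at which 2 of the 2 values shown sit.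

The next compound is compound 3 `C#Cc1cn([C@@H]2O[C@H](CO)[C@@H](O)[C@H]2O)c2ncnc(NC)c12`. It changes compound 2 at one place, with ethynyl in place of 1-benzofuran-2-yl on an aromatic carbon. Ethynyl also stands in compound 1, which reads > 20000 nM, again a limit. Within the data shown here, no measured step shows what this exchange does, so any forecast is loose. Compound 3 may well end at a limit too, but a modest shift toward stronger inhibition is possible. The expected size of the change is an at least 1.6-fold lower number from compound 2 to compound 3 (0.22 log units; that floor lies within the scatter), and this is only an estimate.

For compound 3 the expected value in this assay is 12000 nM, with an estimated range of 1500 nM to 30000 nM.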

Compound 3, half-maximal inhibitory concentration: > 20000 nM
Compound 3 was reported as a limit; the forecaster's own chance of this, stated with the estimate: 60%; at least 1.6-fold (0.22 log units) between middle value and limit.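

In this assay compound 3 gives > 20000 nM, which is a limit. The steps to compound 3 from compound 1 and from compound 2 therefore cannot be read, because the record holds no exact number: the limit of > 20000 nM in this assay, at which 3 of the 3 values shown sit. From the compounds shown here alone, it remains open whether exchanging methylsulfanyl for methylamino, or 1-benzofuran-2-yl for ethynyl, changes the read-out at all.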